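The compounds below may be only part of what the source reports. "The series", "measured", "known", "first", "only" and "open" are said of these compounds alone.

This set concerns three measured compounds and one awaiting measurement, all built on a shared core. Compound 1 `Nc1cc(N)c2nc(-c3ccccc3)c(Oc3ccc(Cl)c(Cl)c3)nc2c1` carries a 3,4-dichlorophenoxy group on that core, and in a functional assay on KM12 cells (Homo sapiens) for inhibition, read by sulforhodamine B assay, with a stated time of 48 h (a lower number here means a stronger inhibitor of growth, a higher number a weaker inhibitor of growth), compound 1 gives 6310 nM. Compound 3 `CCOC(=O)[C@H](CCC(=O)O)NC(=O)c1ccc(Oc2nc3cc(N)cc(N)c3nc2-c2ccccc2)cc1` carries a larger group in that position, and in this assay compound 3 gives 27500 nM. Compound 2 `CCOC(=O)[C@H](CCC(=O)O)NC(=O)c1ccc(CNc2nc3cc(N)cc(N)c3nc2-c2ccccc2)cc1` is a related variant; in this assay compound 2 reaches only a limit of the assay, < 100000 nM, which is the limit of < 100000 nM in this assay, at which 1 of the 3 values shown sits. Among the two real numbers, compound 1 stands lowest, and its gap to compound 3 lies beyond the usual scatter of repeated measurements. The change followed here is 4-fluorophenyl in place of 3,4-dichlorophenyl on an oxygen on an aromatic ring, which gives compound 4 `Nc1cc(N)c2nc(-c3ccccc3)c(Oc3ccc(F)cc3)nc2c1`. Going by the values given here, no measured pair shows this same change, so the step from compound 1 to compound 4 is expected to be moderate and to weaken growth inhibition, a 2.4-fold higher number from compound 1 to compound 4 (0.38 log units; beyond the scatter). For compound 4 in this assay the estimated value is 15000 nM, with a likely range from 4000 nM to 60000 nM.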

Compound 4, concentration for 50% growth inhibition: 14500 nM
Estimate against measurement, compound 4: 1.0-fold (0.01 log units) above; the measured number falls inside the stated range.
By their numbers in this assay, from the lowest: compound 1; then compounds 4 and 3 (each within the scatter of the next).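

Going by these compounds alone, until this result, no two measured compounds differed in one place only, so no single change on this oxygen could be read. In this assay the change from 3,4-dichlorophenyl to 4-fluorophenyl gives a 2.3-fold higher number from compound 1 to compound 4 (0.36 log units; beyond the scatter) and so marks a modest loss of growth inhibition, beyond the usual scatter, which shows that what the ring on this oxygen carries can shift the result. Nothing given here explains this step.

The kind and the number of halogen atoms change together in this one step, so the compounds shown cannot separate the two. On these data alone, how the number would move with a plain phenyl ring, or with a ring carrying a methoxy group or an amine, remains open.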